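This account rests on a few compounds, and the source may have more. Where it says the series, first, only, none or still open, it means among the compounds named here.

Compound 1 `CCOC(=O)C(=O)CC(=O)/C=C/c1cn(Cc2ccc(C#N)cc2)c2ccccc12` – "not determined" (no result reported)
Compound 2 `CCOC(=O)C(=O)CC(=O)/C=C/c1cc(C(=O)c2ccccc2F)c[nH]1` – 15000 nM
Compound 3 `O=C(/C=C/c1cc(C(=O)c2ccccc2F)c[nH]1)CC(=O)C(=O)O` – 20000 nM

Within the data shown here, in a functional assay on MOLT-4 cells (Homo sapiens) for inhibition, read by MTT assay, with a stated time of 48 h (on this read-out lower numbers stand for stronger inhibition and higher numbers for weaker inhibition), compound 3 gives 20000 nM and lies within the scatter of compound 2, the only other compound with a number. Compound 4 `N#Cc1ccc(C(=O)c2c[nH]c(/C=C/C(=O)CC(=O)C(=O)O)c2)cc1` carries 4-cyanophenyl in place of 2-fluorophenyl on a carbonyl carbon. Among the measured compounds shown here, the sole measured step (a 1.3-fold higher number from compound 2 to compound 3 (0.12 log units; within the scatter)) lies elsewhere in the molecule and stays within the scatter. For the measured compounds named here, no measured pair tests this exchange, so no shift beyond the scatter is expected in this assay for it. The estimated step (a 1.1-fold lower number from compound 3 to compound 4 (0.05 log units; within the scatter)) therefore stays small. For compound 4 the estimated value is 18000 nM with an expected range from 6000 nM to 50000 nM in this measurement.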

Compound 4, half-maximal inhibitory concentration: > 40000 nM
Compound 4: only a limit was reported; the forecaster's own chance of this, stated with the estimate: 15%; middle value at least 2.2-fold (0.34 log units) from the limit.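

In this assay, among these compounds, this is the first change to the group on the carbonyl carbon, as the earlier pair differed only at the ethyl on oxygen. From the compounds shown here alone, putting 4-cyanophenyl in place of 2-fluorophenyl gives an at least 2.0-fold higher number from compound 3 to compound 4 (0.30 log units; that floor lies within the scatter), so this step has only a floor and its real size remains unknown. Compound 4 gives a limit of the assay, not a number: the limit of > 40000 nM in this assay, at which 1 of the 4 values shown sits.

A single exchange at this position sets no trend. Going by these compounds, whether an amine or a methoxy group on this phenyl ring would give a number rather than a limit stays open.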